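The source may report more compounds than this note shows. Statements on the series, on what has been measured and on what is new or still open speak of the compounds shown alone.

For the measured compounds named here, in a physicochemical assay for lipophilicity, using the shake flask method, in phosphate buffer, measured as octanol-water partition, with a stated time of 30 min, at pH 7.4 (a higher number here means a more lipophilic compound, a lower number a more polar compound), compound 1 `Cc1nccn1-c1cnc(NCc2c(F)ccc3c2CCO3)c2cn[nH]c(=O)c12` gives 2.1, the lower of the two numbers so far, and compound 2 `O=C1c2ccccc2CN1c1cnc(NCc2c(F)ccc3c2CCO3)n2cnnc12` gives 2.7, a gap beyond the scatter. Compound 3 `CC(=O)N1CCC(c2cnc(NCc3c(F)ccc4c3CCO4)c3cn[nH]c(=O)c23)CC1` differs from compound 1 by one change, 1-acetylpiperidin-4-yl in place of 2-methyl-1H-imidazol-1-yl on an aromatic carbon. Going by the values given here, no measured pair isolates a change in this place, so the expectation rests on the structural change alone. The expected step is slightly downward and not beyond the scatter, a number 0.10 log units lower from compound 1 to compound 3 (within the scatter). For compound 3 the estimate is 2, with an expected range of 1.5 to 2.5.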

Compound 3, distribution coefficient: 2.9
Beside the measured number, compound 3's estimate is 0.90 log units below it, and the stated range ends below it.
By their numbers in this assay, from the lowest: compound 1; then compounds 2 and 3 (each within the scatter of the next).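

In this assay, for the compounds shown here, the first measured step at this position, on an aromatic carbon of the shared core, is a number 0.80 log units higher from compound 1 to compound 3 (beyond the scatter) for 1-acetylpiperidin-4-yl in place of 2-methyl-1H-imidazol-1-yl. The read-out at this position therefore depends on the group placed there, since this exchange of one aromatic ring for a non-aromatic ring bearing an acetyl group moves the number beyond the scatter. On these data alone, this single pair cannot separate the piperidine ring from its acetyl group, and an unacylated piperidin-4-yl amine or a carboxylic acid at this position remains open. No measurement shown explains the step.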